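This account rests on a few compounds, and the source may have more. Where it says the series, first, only, none or still open, it means among the compounds named here.

Among the compounds with values here, compound 1 `O[C@H]1CCCc2nc(C#Cc3ccccc3)ccc21` sits at the weaker end of the two numbers so far: in a functional assay on CHO cells for positive allosteric modulation of metabotropic glutamate receptor 5 (Homo sapiens), read by FLIPR and calcium flux (a lower number here means that less compound is needed, a higher number that more compound is needed for the effect), compound 1 gives 1080 nM, while its ketone counterpart, compound 2 `O=C1CCCc2nc(C#Cc3ccccc3)ccc21`, gives 172 nM in this assay, a gap that lies beyond the scatter of repeated measurements. The next compound, compound 3 `O[C@@H]1CCCc2nc(C#Cc3ccccc3)ccc21`, keeps every atom and bond of compound 1 and changes only the configuration: the two compounds have the same atoms and bonds and differ only in configuration as drawn: 1 of 1 stereo elements differ; a stereocentre at a saturated ring carbon is drawn S in compound 1 and R in compound 3. Within the data shown here, no measured pair in this set shows what inverting this stereocentre does, so the direction of the step is open; a mirror-image change at the only stereocentre can shift the number considerably either way, and the expectation is worded with that width in mind. The step from compound 1 to compound 3 in this assay is estimated as a 2.2-fold lower number from compound 1 to compound 3 (0.33 log units; beyond the scatter). Compound 3 is expected to give 500 nM in this assay, within a range from 80 nM to 3000 nM.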

Compound 3, half-maximal effective concentration: 980 nM
Estimate against measurement, compound 3: 2.0-fold (0.29 log units) below; low and high end bracket the measured number.
By their numbers in this assay, from the lowest: compound 2; then compounds 3 and 1 (each within the scatter of the next).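

At this saturated ring carbon, the configuration of the hydroxyl makes no readable difference in this assay: the step is a 1.1-fold lower number from compound 1 to compound 3 (0.04 log units; within the scatter). The two alcohols thus read as one level, and the printed numbers of both lie on the same side of the ketone compound 2 at 172 nM, so the gap seen earlier between compound 1 and compound 2 does not depend on which configuration is drawn. This pair isolates configuration alone: the fact that compounds 1 and 3 differ only in the configuration as drawn

The compounds shown leave open how other groups at this carbon, such as a methoxy group, an amine or a fluorine, would compare with the ketone and the two alcohols. They also leave open whether configuration at this carbon would remain just as silent with a different substituent elsewhere on the shared core.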